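Swapping the Aryl Group on the Ring Nitrogen

The source may hold more compounds than are shown below. What is called first, only, known or untested is meant among the compounds shown, and "the series" means these compounds.

Measured in a functional assay on HL-60 cells (Homo sapiens) for inhibition, read by MTT assay, with a stated time of 72 h (on this read-out lower numbers stand for stronger inhibition and higher numbers for weaker inhibition), so far:
Compound 1 `Cc1nc(-c2ccccc2)c(C(=O)N2CCN(c3cccc(C)c3C)CC2)o1` gives 35 nM
Compound 2 `C=C(C)c1ccc(N2CCN(C(=O)c3oc(C)nc3-c3ccccc3)CC2)cc1` gives "not active" (no number reported)
Compound 3 `Cc1nc(-c2ccccc2)c(C(=O)N2CCN(c3cc(Cl)cc(Cl)c3)CC2)o1` gives 41.8 nM

Compound 3 gives 41.8 nM and sits within the usual scatter of compound 1, so the two cannot be ranked. Compound 2 has no number to compare with them.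

The next compound is compound 4 `Cc1nc(-c2ccccc2)c(C(=O)N2CCN(c3c(C)cccc3C)CC2)o1` and it differs from compound 3 by one group: 2,6-dimethylphenyl in place of 3,5-dichlorophenyl on an amine nitrogen in a ring and nothing else. The closest evidence is a 1.2-fold higher number from compound 1 to compound 3 (0.08 log units; within the scatter) for exchanging 2,3-dimethylphenyl with 3,5-dichlorophenyl at that same place. That step lies within the scatter, and compound 1 shows that a dimethylphenyl group can give a value of this size. A warning comes from compound 2, reported as "not active" (no number reported) with a different group on that nitrogen, so a change here does not always leave activity intact.

The expected change is a 1.1-fold higher number from compound 3 to compound 4 (0.03 log units; within the scatter) and so no step beyond the scatter in this assay is anticipated. For compound 4 an expected value of 45 nM is estimated, with 13 nM to 160 nM as the likely range.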

Compound 4, half-maximal inhibitory concentration: 146 nM
Compound 4: the middle estimate sits 3.2-fold (0.51 log units) below what was measured; measured number inside the range.
By their numbers in this assay, from the lowest: compounds 1 and 3 (each within the scatter of the next); then compound 4.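

In this assay, the aryl group on the ring nitrogen turns out not to be freely exchangeable, as the earlier pair of compounds with numbers had suggested: this change gives a modest step beyond the scatter (a 3.5-fold higher number from compound 3 to compound 4 (0.54 log units; beyond the scatter)). The more telling comparison is between two groups that both carry two methyl groups on a phenyl ring (a 4.2-fold higher number from compound 1 to compound 4 (0.62 log units; beyond the scatter)): 2,3-dimethylphenyl and 2,6-dimethylphenyl have the same atoms and differ only in where the methyl groups stand, so at this position the placement of the groups on the ring matters, and not only their kind. Nothing measured here explains why this placement changes the number.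

The compounds shown leave open whether 2,6-dichlorophenyl would behave like 2,6-dimethylphenyl or like 3,5-dichlorophenyl, a comparison that would separate the effect of placement from that of the group itself. They also leave open how a phenyl ring with a single methyl group, or one carrying a methoxy group or an amine, would fare at this nitrogen.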